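Aryl ether and thioether variation in the diamine series

The source may hold more compounds than are shown below. What is called first, only, known or untested is meant among the compounds shown, and "the series" means these compounds.

Compound 3 `Nc1cc(N)c2nc(-c3ccccc3)c(Sc3ccc(Cl)c(Cl)c3)nc2c1` carries a (3,4-dichlorophenyl)sulfanyl group on the shared core. In a functional assay on OVCAR-3 cells (Homo sapiens) for inhibition, read by sulforhodamine B assay, with a stated time of 48 h (a lower number here means that less compound is tolerated, a higher number that more compound is tolerated), compound 3 gives only a limit of < 100000 nM and no number. Compound 2 `Nc1cc(N)c2nc(-c3ccccc3)c(NCc3ccc(F)cc3)nc2c1`, with a (4-fluorobenzyl)amino group at the same place, likewise returns only a limit of < 100000 nM in this assay. Within the data shown here, compound 1 `Nc1cc(N)c2nc(-c3ccccc3)c(Oc3ccc(Cl)c(Cl)c3)nc2c1` is the one member of the set with a number: in this assay compound 1 gives 66100 nM. The steps a step that the limit leaves unreadable from compound 1 to compound 3, a step that the limit leaves unreadable from compound 1 to compound 2 and a step that the two limits leave unreadable from compound 2 to compound 3 are therefore all unreadable, which follows from the limit of < 100000 nM in this assay, at which 2 of the 3 values shown sit.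

Compound 4 `Nc1cc(N)c2nc(-c3ccccc3)c(Oc3ccc(F)cc3)nc2c1` is the next candidate for this assay. The change from compound 3 is 4-fluorophenoxy in place of (3,4-dichlorophenyl)sulfanyl on an aromatic carbon. Among the measured compounds shown here, none of the measured steps bears on this exchange in readable size; the nearest comparison is compound 1, which shares the aryl ether link and gives 66100 nM. On that basis compound 4 is expected to sit in the same upper region of this assay, with the step that the limit leaves unreadable from compound 3 to compound 4 expected to stay within or near the scatter. The estimate for compound 4 in this assay is 70000 nM, between 30000 nM and 160000 nM.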

Compound 4, concentration lethal to 50% of the cells: < 100000 nM
Compound 4 gave a limit, no number; the forecaster's own chance of this, stated with the estimate: 40%; the middle value is on the limit's open side.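

Compound 4 gives only a limit of < 100000 nM in this assay and no number. Among these compounds, no step from compound 1, compound 2 or compound 3 to compound 4 can be read, which follows from the limit: the limit of < 100000 nM in this assay, at which 3 of the 4 values shown sit. Left open is whether 4-fluorophenoxy, 3,4-dichlorophenoxy, (3,4-dichlorophenyl)sulfanyl and (4-fluorobenzyl)amino on the shared core differ at all in this assay.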